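Propargyloxy in Place of the Thioether Ester on a Second Core

A few compounds are considered here, and "the series" means these few. Any claim that something is new, unique, unknown or untested is made for them only; others in the source may bear on it.

Compound 1 `COC(=O)CSc1cc(-n2c(=S)n3n(c2=S)CCCC3)c(F)cc1Cl` carries a ((methoxycarbonyl)methyl)sulfanyl group on its six-membered aromatic ring of carbon only. In a functional assay on the whole organism for inhibition, with Scenedesmus acutus as the target (on this read-out lower numbers stand for stronger inhibition and higher numbers for weaker inhibition), compound 1 gives 186 nM. Compound 2 `C#CCOc1cc(-n2c(=S)n3n(c2=S)CCCC3)c(F)cc1Cl` differs from it in one place, (propargyloxy in place of ((methoxycarbonyl)methyl)sulfanyl on an aromatic carbon), and in this assay compound 2 gives 2.04 nM. That single exchange made a 91-fold lower number from compound 1 to compound 2 (1.96 log units; beyond the scatter).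

Compound 3 `COC(=O)CSc1cc(/N=c2\sc(=S)n3n2CCCC3)c(F)cc1Cl` is built from the same atoms as compound 1, joined differently; the difference between the two cores is not broken down here. In this assay compound 3 gives 245 nM, a number that lies within the usual scatter of compound 1, so the two cores behave alike while both carry the thioether ester.

Compound 4 `C#CCOc1cc(/N=c2\sc(=S)n3n2CCCC3)c(F)cc1Cl` applies to compound 3 the change already seen once, (propargyloxy in place of ((methoxycarbonyl)methyl)sulfanyl on an aromatic carbon), at a place described in the same words as before: on an aromatic carbon, ortho to a chloro group, meta to a large group, para to a fluoro group. For the measured compounds named here, since the two cores gave matching numbers with the thioether ester in place, the step from compound 3 to compound 4 is expected to resemble the one from compound 1 to compound 2, and it is estimated as an 82-fold lower number from compound 3 to compound 4 (1.91 log units; beyond the scatter). On that basis compound 4 is expected to give about 3 nM in this assay, with a likely range from 1 nM to 12 nM.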

Compound 4, half-maximal inhibitory concentration: 7.24 nM
The estimate for compound 4 lay 2.4-fold (0.38 log units) below the measured number, and the stated range covers the measured number.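

On the second core, the exchange of ((methoxycarbonyl)methyl)sulfanyl for propargyloxy again moves the number strongly in the same direction in this assay, with a 34-fold lower number from compound 3 to compound 4 (1.53 log units; beyond the scatter). The direction of the change therefore carries over from one core to the other, but its size does not carry over unchanged: the same change on two cores in this assay, a 91-fold lower number (1.96 log units; beyond the scatter) from compound 1 to compound 2 and a 34-fold lower number (1.53 log units; beyond the scatter) from compound 3 to compound 4, 2.7-fold (0.43 log units) apart, beyond the scatter of two such steps. Two cores make only two cases: they give no rule for any further core, and they do not say what in the cores sets the gap between the two steps.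

The exchange alters the atom attached to the aromatic carbon and the chain beyond it in a single move, so the compounds shown leave open which of the two matters, a question that a propargylsulfanyl group or a (methoxycarbonyl)methoxy group at the same place on each core would begin to separate. They also leave open how much depends on the triple bond itself and how much on the chain length, and how a plain methoxy group, an allyloxy group, a longer chain such as butynyloxy or a carboxylic acid in place of the methyl ester would read on the two cores.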